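The compounds below may be only part of what the source reports. "The series", "measured", "known", "first", "only" and "open" are said of these compounds alone.

Series notes, compound 2 to compound 4.

Compound 2 `FC(F)(F)c1ccc(-c2ccc3c(NCCCNCc4ccco4)ccnc3c2)cc1` gives 32000 nM in a physicochemical assay for solubility, with a stated time of 18 h, at pH 7.4 (on this read-out lower numbers stand for lower solubility and higher numbers for higher solubility), the highest number among the three measured compounds. Compound 1 `COc1cccc(CNCCCNc2ccnc3cc(Oc4ccccc4)ccc23)c1O` gives 14500 nM in this assay, and compound 3 `COc1cccc(CNCCCNc2ccnc3cc(Cc4cccc(C(F)(F)F)c4)ccc23)c1O` gives 4200 nM in this assay; both gaps from compound 2 lie beyond the scatter.

Compound 4 `COc1ccc(Oc2ccc3c(NCCCNCc4ccco4)ccnc3c2)cc1` is not yet measured. It differs from compound 2 in one place: 4-methoxyphenoxy in place of 4-(trifluoromethyl)phenyl on an aromatic carbon.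

For the measured compounds named here, the only single-point step measured so far is a 3.5-fold lower number from compound 1 to compound 3 (0.54 log units; beyond the scatter), where 3-(trifluoromethyl)benzyl in place of phenoxy went with a lower number in this assay. The change from compound 2 to compound 4 runs the other way: 4-(trifluoromethyl)phenyl leaves and 4-methoxyphenoxy enters, at a place meta to a fused ring and para to a fused ring. Going by the values given here, no measured step covers the methoxy group or the direct attachment of 4-(trifluoromethyl)phenyl, so the bearing of that one step is indirect. A move in this assay toward a higher number is expected, of about the size seen before or smaller, and an outcome within the scatter cannot be ruled out.

Compound 4 is expected to give 60000 nM in this assay, within 25000 nM to 150000 nM. The expected step is a 1.9-fold higher number from compound 2 to compound 4 (0.27 log units; within the scatter).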

Compound 4, solubility: 14500 nM
Estimate against measurement, compound 4: 4.1-fold (0.62 log units) above, and the stated range ends above it.
By their numbers in this assay, from the lowest: compound 3; then compounds 1 and 4 (each within the scatter of the next); then compound 2.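

For the compounds shown here, at this position, on an aromatic carbon para to a fused ring, 4-methoxyphenoxy in place of 4-(trifluoromethyl)phenyl goes with a 2.2-fold lower number from compound 2 to compound 4 (0.34 log units; beyond the scatter) in this assay and so gives a first single-place reading for the side chain of compound 2. The entering group counts 2 hydrogen-bond acceptors against 0 for the leaving group and has one heavy atom fewer, yet the number falls, so in this pair neither count goes with a higher number. The earlier step, a 3.5-fold lower number from compound 1 to compound 3 (0.54 log units; beyond the scatter), had phenoxy on its higher side, while here the group with the oxygen link is on the lower side, so across these two steps, which sit on different side chains, an aryl ether at this place shows no single direction, and no measurement given here accounts for either step.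

The compounds shown do not separate the oxygen link from the methoxy group within this change, as 4-methoxyphenyl and unsubstituted phenoxy do not appear on this side chain. On these data alone, how a carboxylic acid or a morpholine on the same aromatic ring would read in this assay also remains open.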